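The source may hold more compounds than are shown below. What is called first, only, known or untested is meant among the compounds shown, and "the series" means these compounds.

In a functional assay on HBL-100 cells (Homo sapiens) for inhibition, read by sulforhodamine B assay, with a stated time of 48 h (on this read-out higher numbers stand for weaker inhibition of growth and lower numbers for stronger inhibition of growth), compound 1 `CC(=O)OC/C(=C\C1CCCCC1)C(=O)c1ccccc1` gives 21000 nM, and compound 3 `CC(=O)OC/C(=C\c1ccccc1Br)C(=O)c1ccccc1` gives 22000 nM. Compound 2 `CCC(/C=C(\COC(C)=O)C(=O)c1ccccc1)CC` reaches only the limit of > 100000 nM in this assay, so no number is known for it. Of the two numbers, compound 3 sits at the higher end, yet the step of a 1.0-fold higher number from compound 1 to compound 3 (0.02 log units; within the scatter) lies within the scatter, so compound 1 and compound 3 cannot be told apart. Compound 4 `CC(=O)OC/C(=C\c1ccccc1[N+](=O)[O-])C(=O)c1ccccc1` differs from compound 3 by nitro in place of bromo on an aromatic carbon. Among the compounds with values here, no measured step alters a group on the aromatic ring; the steps seen, an at least 4.7-fold higher number from compound 1 to compound 2 (0.67 log units; beyond the scatter) and an at least 4.5-fold lower number from compound 2 to compound 3 (0.65 log units; beyond the scatter), exchange the whole group on the chain carbon. In this assay the step of no change at the digits printed from compound 3 to compound 4 (within the scatter) is therefore expected to stay within the scatter. Compound 4 is expected to give 22000 nM, between 7000 nM and 70000 nM.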

Compound 4, concentration for 50% growth inhibition: 26000 nM
For compound 4 the middle estimate is 1.2-fold (0.07 log units) below the measured one, within the range that was stated.
By their numbers in this assay, from the lowest: compounds 1, 3 and 4 (each within the scatter of the next). At a limit, above all of these: compound 2.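

In this assay, within the data shown here, the first exchange on the aromatic ring itself, on a carbon ortho to a large group, gives a 1.2-fold higher number from compound 3 to compound 4 (0.07 log units; within the scatter). At this position, bromo with 1 heavy atom and no hydrogen-bond acceptors and nitro with 3 heavy atoms and 2 hydrogen-bond acceptors cannot be told apart. Nothing measured here accounts for this result.

Still open, as far as these compounds go, is whether an amine or a carboxylic acid on this same carbon would also stay within the scatter. Also open, from the compounds shown here alone, is how bromo or nitro would fare elsewhere on the ring.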